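A Bromo Substituent Added to Two Related Cores

This account rests on a few compounds, and the source may have more. Where it says the series, first, only, none or still open, it means among the compounds named here.

Measured compounds:
compound 1, `CN(C)C1(COc2cccnc2)CC1`, 95 nM
compound 2, `CNC1(COc2ccc(Cl)nc2)CC1`, 13 nM
compound 3, `CN(C)C1(COc2cncc(Br)c2)CC1`, 273 nM

These three compounds were tested in an assay on brain for displacement of a labelled ligand from Neuronal acetylcholine receptor; alpha4/beta2 (Rattus norvegicus); on this read-out higher numbers stand for weaker inhibition and lower numbers for stronger inhibition. Compound 2 gives the lowest number; compound 1 stands closer to it, and compound 3 stands farthest away. The difference between the core of compound 2 and the core of compound 1 is not broken down here.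

Compound 4, `CNC1(COc2cnc(Cl)c(Br)c2)CC1`, has not yet been tested. It arises from compound 2 by the change (bromo in place of hydrogen on an aromatic carbon). The same kind of change has already been made once, from compound 1 to compound 3: bromo in place of hydrogen on an aromatic carbon. The surroundings are not quite the same: in compound 4 the bromo sits ortho to a chloro group and meta to a group of 7 heavy atoms, whereas in compound 3 it sits meta to a group of 8 heavy atoms. That earlier step gave a 2.9-fold higher number from compound 1 to compound 3 (0.46 log units; beyond the scatter). Taking it as the guide, a step of about the same size is expected here, a 2.9-fold higher number from compound 2 to compound 4 (0.47 log units; beyond the scatter), because compound 2 starts from 13 nM and the earlier change gave a 2.9-fold higher number from compound 1 to compound 3 (0.46 log units; beyond the scatter). Compound 4 is therefore estimated at 38 nM, most likely between 15 nM and 100 nM.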

Compound 4, inhibition constant: 5.37 nM
Beside the measured number, compound 4's estimate is 7.1-fold (0.85 log units) above it, outside the stated range (below it).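

In this assay putting bromo in place of hydrogen on an aromatic carbon of compound 2 gives a 2.4-fold lower number from compound 2 to compound 4 (0.38 log units; beyond the scatter) and so moves the number the opposite way from the earlier step. The change therefore does not carry over from one core to the other in direction or in size, and the earlier step alone was a poor guide here: the same change on two cores in this assay, a 2.9-fold higher number (0.46 log units; beyond the scatter) from compound 1 to compound 3 and a 2.4-fold lower number (0.38 log units; beyond the scatter) from compound 2 to compound 4, 7.0-fold (0.84 log units) apart, beyond the scatter of two such steps.

Within the data shown here, the two cores differ from each other in more than one place, and each has only one such pair, so this does not show which difference goes with the opposite outcome, nor how the change would behave on any further core.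

The compounds shown leave open how the step would run on a core that combines the amine of compound 1 with the chloro group of compound 2. They also leave open whether another group on the same aromatic carbon, such as fluoro or a nitrile, would follow bromo on either core.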